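A few compounds are considered here, and "the series" means these few. Any claim that something is new, unique, unknown or untested is made for them only; others in the source may bear on it.

Measured compounds, all in a functional assay on MCF7 cells (Homo sapiens) for antiproliferative activity, read by MTT assay, with a stated time of 72 h (on this read-out higher numbers stand for weaker inhibition and lower numbers for stronger inhibition), as the read-out:
- compound 1 `COc1cccc(N2C(=O)COc3ccc(-c4cnc(OC)c(NS(=O)(=O)c5ccc(F)cc5)c4)cc32)c1` gives > 40000 nM (a limit)
- compound 2 `COc1ncc(-c2ccc3c(c2)N(c2ccc(F)cc2)C(=O)CO3)cc1NS(=O)(=O)c1ccc(F)cc1` gives > 40000 nM (a limit)
- compound 3 `COc1ncc(-c2ccc3c(c2)N(c2ccc(Cl)cc2)C(=O)CO3)cc1NS(=O)(=O)c1ccc(F)cc1` gives 27600 nM

Among the measured compounds shown here, compound 3 stands at 27600 nM as the only actual number of the three. The other two results are limits, and the set holds the limit of > 40000 nM in this assay, at which 2 of the 3 values shown sit, as its main feature.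

The next step leads to compound 4 `COc1ncc(-c2ccc3c(c2)N(C(C)C)C(=O)CO3)cc1NS(=O)(=O)c1ccc(F)cc1`, with isopropyl in place of 4-chlorophenyl on an amide-type nitrogen in a ring.

For the measured compounds named here, three measured steps bear on this place: (an at least 1.4-fold lower number from compound 1 to compound 3 (0.16 log units; that floor lies within the scatter)), (an at least 1.4-fold lower number from compound 2 to compound 3 (0.16 log units; that floor lies within the scatter)) and (a step that the two limits leave unreadable from compound 1 to compound 2). All three exchange one substituted phenyl group for another. Neither readable floor goes beyond the scatter, and the third step has no readable size. Going by the values given here, no measured compound carries a group without a ring on this nitrogen, so the steps offer neither a size nor a direction for this change.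

The expectation in this assay is therefore no shift beyond the scatter, and a report at the limit is about as likely as a number. The expected step is (a 1.1-fold lower number from compound 3 to compound 4 (0.04 log units; within the scatter)).

The estimate for compound 4 is 25000 nM with an expected range from 6000 nM to 60000 nM as its span.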

Compound 4, half-maximal inhibitory concentration: 17000 nM
Compound 4: the middle estimate sits 1.5-fold (0.17 log units) above what was measured; low and high end bracket the measured number.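

Compound 4 is the only compound shown with a group without a ring on the amide-type nitrogen, and in this assay the exchange of 4-chlorophenyl for isopropyl gives a 1.6-fold lower number from compound 3 to compound 4 (0.21 log units; within the scatter), so on these two compounds a six-membered aromatic ring at this position is not required for a value inside the measurable range. Against the other two aryl groups, isopropyl gives steps that pass the scatter, with an at least 2.3-fold lower number from compound 2 to compound 4 (0.37 log units; beyond the scatter) and an at least 2.3-fold lower number from compound 1 to compound 4 (0.37 log units; beyond the scatter), so the series now shows a readable difference at this nitrogen, with compound 3 as the aryl case that stays level with compound 4. Both of those steps are floors rather than sizes, as each starts from a limit: the limit of > 40000 nM in this assay, at which 2 of the 4 values shown sit.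

As far as these compounds go, the true size of those two steps stays open, as does the reading for a methyl group, a longer chain, or a chain ending in an amine or a carboxylic acid on this nitrogen. The rest of the core is the same in all four compounds, so these results say nothing about changes elsewhere in the structure.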